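A few compounds are considered here, and "the series" means these few. Any claim that something is new, unique, unknown or untested is made for them only; others in the source may bear on it.

Measured in an ADME assay on HEK293 cells (Homo sapiens) for cytotoxicity, read by MTT assay, with a stated time of 72 h; on this read-out lower numbers stand for stronger inhibition and higher numbers for weaker inhibition:

Compound 1 `COc1cc(/C=C/c2cc(C)[nH]n2)ccc1O`: 47700 nM
Compound 2 `Cc1cc(/C=C/c2ccc(O)c(O)c2)on1`: 13000 nM
Compound 3 `COc1ccc(/C=C/c2cc(C)n[nH]2)cc1OC`: 23200 nM

Compound 2 has the lowest number of the three at 13000 nM, though this does not set it apart from every other compound. Its value lies within the usual scatter of compound 3 at 23200 nM, while compound 1 at 47700 nM stands higher, beyond the scatter.

The next compound, compound 4 `COc1cc(/C=C/c2cc(C)no2)ccc1O`, differs from compound 2 by methyl in place of hydrogen on an oxygen on an aromatic ring, or hydroxy to methoxy. Going by the values given here, no measured pair isolates this change, so the evidence is indirect. Methoxy groups occur in compound 1, at 47700 nM, and in compound 3, at 23200 nM, but the cores of both differ from that of compound 2. Compound 1 hints at a higher number, whereas compound 3 shows no separation from compound 2 and so goes against that hint.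

A modest move towards weaker inhibition is therefore expected, with the estimated step of a 1.8-fold higher number from compound 2 to compound 4 (0.27 log units; within the scatter) possibly not exceeding the scatter. For compound 4, the estimated value in this assay is 24000 nM, with an expected range of 9000 nM to 60000 nM.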

Compound 4, half-maximal inhibitory concentration: 36200 nM
The estimate for compound 4 lay 1.5-fold (0.18 log units) below the measured number; the measured number falls inside the stated range.
By their numbers in this assay, from the lowest: compounds 2, 3, 4 and 1 (each within the scatter of the next, the first and the last beyond it).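

In this assay, going by these compounds alone, the pair of compound 2 and compound 4 gives the first direct reading of methyl in place of hydrogen on an oxygen on an aromatic ring, or hydroxy to methoxy, with the core held constant. The change gives a 2.8-fold higher number from compound 2 to compound 4 (0.44 log units; beyond the scatter), so at this position it moves the number towards weaker inhibition by more than the usual scatter. Compound 1 and compound 3 also carry methoxy groups, but their cores differ from that of compound 2, so they could give only indirect and conflicting hints, whereas this pair isolates the change at this one oxygen. Nothing shown here gives a measured reason for the step.

The compounds shown leave open whether the same change would give a step of similar size on the core of compound 1 or that of compound 3, since neither has a partner differing only at this oxygen. They also leave open how this position would respond to an ethoxy group, a longer chain on the oxygen, or an amine in place of the hydroxy group.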